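The source may hold more compounds than are shown below. What is called first, only, known or untested is meant among the compounds shown, and "the series" means these compounds.

Measured compounds in an assay on membranes from brain for displacement of a labelled ligand from Sigma non-opioid intracellular receptor 1 (Cavia porcellus), read by scintillation counting, with a stated time of 120 min; a lower number here means a stronger inhibitor, a higher number a weaker inhibitor:

compound 1, `COc1ccc(CN2CCCN(Cc3ccccc3)[C@@H](C)C2)cc1`: 0.86 nM
compound 2, `COc1ccc(CN2CCCN(Cc3ccccc3)[C@H](C)C2)cc1`: 0.51 nM
compound 3, `C[C@@H]1CN(CCCCc2ccccc2)CCCN1Cc1ccccc1`: 0.83 nM

Compound 1 is the reference for the next step. For the measured compounds named here, its value in this assay lies within the scatter of the other two: compound 3 gives a value that is practically the same, and the step of a 1.7-fold lower number from compound 1 to compound 2 (0.23 log units; within the scatter) is also within the scatter, which is all the series so far says about the configuration at the ring carbon (the fact that compounds 1 and 2 differ only in the configuration as drawn).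

Compound 4, `COc1ccc(CN2CCCN(Cc3ccccc3)[C@@H](C(C)C)C2)cc1`, is not yet measured. It differs from compound 1 in one place: isopropyl in place of methyl on a saturated ring carbon. Going by the values given here, none of the measured steps changes the size of this alkyl group; the only step on the shared core concerns its configuration and is within the scatter. There is thus no measured basis for a large change in either direction, and the expectation is a step no larger than the scatter, with some allowance for a weaker value given the larger group. Compound 4 is therefore estimated at 1.5 nM, in the range 0.4 nM to 6 nM, corresponding to an expected step of a 1.7-fold higher number from compound 1 to compound 4 (0.24 log units; within the scatter).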

Compound 4, inhibition constant: 20 nM
Beside the measured number, compound 4's estimate is 13-fold (1.12 log units) below it; measured number above the stated range.
By their numbers in this assay, from the lowest: compounds 2, 3 and 1 (each within the scatter of the next); then compound 4.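

In this assay, isopropyl in place of methyl on this saturated ring carbon gives a 23-fold higher number from compound 1 to compound 4 (1.37 log units; beyond the scatter), the only step shown that lies beyond the scatter. The position is therefore sensitive to the alkyl group it carries, which could not be seen from the change of configuration alone, a 1.7-fold lower number from compound 1 to compound 2 (0.23 log units; within the scatter). Nothing in the data shown accounts for the size of this step.

Open, as far as these compounds go, is whether the number rises gradually with the size of the group, which an ethyl group on this carbon would test, and how a hydroxymethyl or aminomethyl group there would compare. Also open, from the compounds shown here alone, is whether isopropyl in the opposite configuration gives a value close to that of compound 4.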